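A few compounds are considered here, and "the series" means these few. Any claim that something is new, unique, unknown or untested is made for them only; others in the source may bear on it.

Compound 1 `ClCc1ccc(Cn2cnc3c(Cl)ncnc32)cc1` gives 640 nM in a functional assay on CAKI-1 cells (Homo sapiens) for cytotoxicity, read by sulforhodamine B assay, with a stated time of 48 h; on this read-out lower numbers stand for stronger inhibition of growth and higher numbers for weaker inhibition of growth.
Compound 2 `ClCc1ccccc1Cn1cnc2c(Cl)nc(Cl)nc21` gives 890 nM in this assay.

Compound 2 stands at the higher of the two numbers measured in this assay, but its nearest neighbour, compound 1, lies within the usual scatter of it, so the two cannot be told apart on these data. Among the measured compounds shown here, no step between the two measured compounds is available, since they differ in more than one place.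

Compound 3 `ClCc1ccccc1Cn1cnc2c(Cl)ncnc21` is reached from compound 2 by one change: hydrogen in place of chloro on an aromatic carbon. The result is a compound that shares its core with compound 1 while keeping the benzyl arm of compound 2. Compound 1 with that same core gave 640 nM, and compound 2 gave 890 nM, so no step beyond the scatter is expected in this assay for this change. The expected step is a 1.2-fold lower number from compound 2 to compound 3 (0.07 log units; within the scatter). Compound 3 is estimated at 750 nM, with a range from 300 nM to 1900 nM.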

Compound 3, concentration for total growth inhibition: 4170 nM
Compound 3: the middle estimate sits 5.6-fold (0.75 log units) below what was measured; measured number above the stated range.
By their numbers in this assay, from the lowest: compounds 1 and 2 (each within the scatter of the next); then compound 3.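

Replacing chloro with hydrogen on the aromatic carbon between two ring nitrogen atoms gives a 4.7-fold higher number from compound 2 to compound 3 (0.67 log units; beyond the scatter) in this assay and this step lies beyond the scatter. Compounds 1 and 2 differ in more than one place and could not isolate this position, whereas this pair shows that the chloro group goes with the lower number here. That holds for this single pair only, and nothing available explains the step.

From the compounds shown here alone, whether an amine, a methoxy group or fluoro at this position would stay close to compound 2 or to compound 3 remains open. Also open, going by these compounds, is whether the same change would give a similar step with the chloromethyl group placed as in compound 1.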